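A few compounds are considered here, and "the series" means these few. Any claim that something is new, unique, unknown or untested is made for them only; others in the source may bear on it.

Among the compounds with values here, compound 2 `COc1ccc(-c2cc(C(=O)Nc3ccc(Oc4ccnc5cc(OCCCN6CCC(C)CC6)c(OC)cc45)c(F)c3)c3ccccc3n2)cc1` is one of two compounds measured in a functional assay on SMMC-7721 cells (Homo sapiens) for cytotoxicity, read by MTT assay, with a stated time of 72 h (a higher number here means a weaker inhibitor, a lower number a stronger inhibitor), where compound 2 gives 450 nM. This is the higher of the two numbers. Within the data shown here, its only neighbour is compound 1 `COc1cc2c(Oc3ccc(NC(=O)c4cc(-c5cccc(Cl)c5)nc5ccccc45)cc3F)ccnc2cc1OCCCN1CCC(C)CC1`, which in this assay gives 80 nM; the single change between them, 4-methoxyphenyl in place of 3-chlorophenyl on an aromatic carbon, produced a 5.6-fold higher number from compound 1 to compound 2 (0.75 log units; beyond the scatter). Compound 3 `COc1cc2c(Oc3ccc(NC(=O)c4cc(-c5ccc(C)cc5)nc5ccccc45)cc3F)ccnc2cc1OCCCN1CCC(C)CC1` differs from compound 2 in one place: methyl in place of methoxy on an aromatic carbon, that is, 4-methoxyphenyl becomes 4-methylphenyl.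

Among the measured compounds shown here, only one measured step bears on this change, and it touches the same ring: the step of a 5.6-fold higher number from compound 1 to compound 2 (0.75 log units; beyond the scatter) shows that altering the group on this phenyl ring can shift the number well beyond the usual scatter. For the measured compounds named here, no measured pair compares methyl with methoxy directly, so the direction is uncertain. Since compound 1 carries a non-oxygen substituent on this ring and gives 80 nM, a modest move downward from compound 2 seems the more likely outcome, expected as a 2.3-fold lower number from compound 2 to compound 3 (0.35 log units; beyond the scatter). Compound 3 is therefore estimated at 200 nM, with a range from 70 nM to 600 nM.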

Compound 3, half-maximal inhibitory concentration: 1260 nM
The estimate for compound 3 lay 6.3-fold (0.80 log units) below the measured number, outside the stated range (above it).
By their numbers in this assay, from the lowest: compound 1; then compound 2; then compound 3.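

In this assay, methyl in place of methoxy gives a 2.8-fold higher number from compound 2 to compound 3 (0.45 log units; beyond the scatter) and so the number rises when the ring loses its oxygen-bearing group, a direct comparison of these two groups that the earlier pair could not give. The step to the chlorine-bearing compound is larger, at a 16-fold higher number from compound 1 to compound 3 (1.20 log units; beyond the scatter) and with compound 2 falling between these two, the oxygen-free 3-chlorophenyl and 4-methylphenyl groups sit at opposite ends of the three numbers, so lacking oxygen does not alone set the number here, although that step changes both the substituent and where it sits on the ring. No measurement shown here explains why methyl gives the higher number in this series or why the chlorine-bearing compound gives the lowest.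

The three compounds leave open whether chlorine or its location on the ring accounts for most of the gap, which 4-chlorophenyl or 3-methylphenyl would help to separate. They also leave open how the unsubstituted phenyl group or a 4-aminophenyl group would compare on the same core.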